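Switching chloro for nitro on the enone aryl ring

The source may hold more compounds than are shown below. What is called first, only, known or untested is meant among the compounds shown, and "the series" means these compounds.

The shared core is carried by compound 1 `COC(=O)c1cc(-c2cccc(NC(=O)c3ccc(OCc4ccc(Cl)cc4)cc3)c2)on1`, compound 2 `COC(=O)c1cc(-c2cccc(NC(=O)c3ccc(/C=C/C(=O)c4cccc(Cl)c4)cc3)c2)on1` and compound 3 `COC(=O)c1cc(-c2cccc(NC(=O)/C=C/c3ccc(Cl)cc3)c2)on1`. In an ADME assay on Vero cells (Chlorocebus sabaeus) for cytotoxicity, read by MTT assay, with a stated time of 72 h (on this read-out higher numbers stand for lower toxicity in this test and lower numbers for higher toxicity in this test), compound 1 reaches only a limit of the test, > 80 ug/mL. In this assay compound 2 likewise reaches only a limit, > 2.5 ug/mL. For compound 3 the result in this assay is "not determined" (no result reported). Among the measured compounds shown here, the one single-point step, a step that the two limits leave unreadable from compound 1 to compound 2, is therefore a step whose size the two limits do not let one read, so compound 2 stands on a limit with no measured neighbour to place it above or below.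

The step to compound 4 `COC(=O)c1cc(-c2cccc(NC(=O)c3ccc(/C=C/C(=O)c4cccc([N+](=O)[O-])c4)cc3)c2)on1` is nitro in place of chloro on an aromatic carbon. For the measured compounds named here, no measured step changes this ring, and the only step to hand, a step that the two limits leave unreadable from compound 1 to compound 2, gives no readable size, so no direction can be expected beyond the scatter. Compound 4 is therefore estimated at 20 ug/mL, between 4 ug/mL and 80 ug/mL, an expected step that the limit leaves unreadable from compound 2 to compound 4.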

Compound 4, half-maximal cytotoxic concentration: > 40 ug/mL
Compound 4 ended at the assay's limit; the forecaster's own chance of this, stated with the estimate: 60%; middle value at least 2.0-fold (0.30 log units) away from the limit.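

Among the compounds shown here, compound 2 and compound 4 both rest only on limits in this assay, so the change from chloro to nitro between them gives no new step of readable size. The compounds shown leave open whether this change shifts the cytotoxic concentration at all, and in which direction.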